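Amide aryl swap in the phenylacetic acid series

A few compounds are considered here, and "the series" means these few. Any claim that something is new, unique, unknown or untested is made for them only; others in the source may bear on it.

Measured so far in an assay on CHO cells for displacement of a labelled ligand from prostaglandin D2 receptor (Mus musculus), read by scintillation counting, with a stated time of 60 min; on this read-out lower numbers stand for stronger inhibition and higher numbers for weaker inhibition:
compound 1 `CN1C[C@@H](COc2ccc(C(=O)N(C)c3cccc(CC(=O)O)c3)cc2)Oc2ccccc21`: 760 nM
compound 2 `CN1C[C@@H](COc2ccc(C(=O)Nc3cccc(CC(=O)O)c3)c(Cl)c2)Oc2ccccc21`: 16 nM
compound 3 `Cc1cc(OC[C@@H]2CN(C)c3ccccc3O2)ccc1C(=O)Nc1cccc(CC(=O)O)c1C`: 59 nM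

Compound 3 holds the second-highest number of the three in this assay. Its nearest neighbour is compound 2, whose number is lower by a margin beyond the usual scatter; compound 1 sits furthest away, with a markedly higher number, also beyond the scatter. Going by the values given here, no pair among the three differs in a single place, so no isolated step is available from the measured set.

Compound 4 `Cc1cc(OC[C@@H]2CN(C)c3ccccc3O2)ccc1C(=O)Nc1cc(CC(=O)O)ccc1Cl` is compound 3 with one change: 5-(carboxymethyl)-2-chlorophenyl in place of 3-(carboxymethyl)-2-methylphenyl on an amide-type nitrogen. The carboxymethyl chain stays on the aryl group, but on a different ring position, and a chlorine replaces the methyl. Among the compounds with values here, nothing among the measured compounds isolates either part of this change; the chlorine-bearing compound 2 carries its chlorine on the other aryl ring, so it gives no direct guide.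

The expectation for compound 4 is therefore a step of a 1.3-fold lower number from compound 3 to compound 4 (0.12 log units; within the scatter), not clearly beyond the scatter in either direction. Compound 4 is estimated at 45 nM, in the range 12 nM to 170 nM.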

Compound 4, inhibition constant: 7.7 nM
The estimate for compound 4 lay 5.8-fold (0.77 log units) above the measured number, and the stated range ends above it.
By their numbers in this assay, from the lowest: compound 4; then compound 2; then compound 3; then compound 1.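

In this assay the aryl group on the amide-type nitrogen proves to be a sensitive place in this series: the step of a 7.7-fold lower number from compound 3 to compound 4 (0.88 log units; beyond the scatter) lies beyond the scatter, with the rest of the molecule unchanged. The swap of 3-(carboxymethyl)-2-methylphenyl for 5-(carboxymethyl)-2-chlorophenyl leaves the heavy-atom, hydrogen-bond donor and hydrogen-bond acceptor counts as they were, so these counts do not track the step. No measured evidence bears on the origin of this step.

The step joins two changes, the ring position of the carboxymethyl chain and chlorine in place of methyl, and the compounds shown do not separate them. Also open, going by these compounds, is how a bromine or a trifluoromethyl group in place of the chlorine, or a longer carboxyethyl chain in place of carboxymethyl, would read here.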